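The compounds below may be only part of what the source reports. "The series", "measured", "known", "first", "only" and "open" are said of these compounds alone.

The measured compounds:
Compound 1, `C=C[C@@](C)(/C=C/c1ccc(Nc2ccc(F)c(F)c2)cc1)CCC=C(C)C`: in an ADME assay on BJ cells (Homo sapiens) for cytotoxicity, with a stated time of 72 h (on this read-out higher numbers stand for an effect only at larger amounts of compound and lower numbers for an effect already at smaller amounts), compound 1 gives > 36600 nM, which is a limit of the assay and not a number.
Compound 2, `C=C[C@@](C)(/C=C/c1ccc(Nc2cc(F)cc(F)c2)cc1)CCC=C(C)C`: in this assay compound 2 gives > 36600 nM, also a limit.
Compound 3, `C=C[C@@](C)(/C=C/c1ccc(-c2cccc(F)c2)cc1)CCC=C(C)C`: in this assay compound 3 gives > 36600 nM, again a limit.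

Compound 3 thus stands only at the edge of what the assay reports, and every value shown sits at that same edge (the limit of > 36600 nM in this assay, at which 3 of the 3 values shown sit). The change to compound 4 `C=C[C@@](C)(/C=C/c1ccc(-c2cccc(Br)c2)cc1)CCC=C(C)C` is bromo in place of fluoro on an aromatic carbon. The steps a step that the two limits leave unreadable from compound 1 to compound 2, a step that the two limits leave unreadable from compound 1 to compound 3 and a step that the two limits leave unreadable from compound 2 to compound 3 cannot be read, since both of their ends sit at the limit (the limit of > 36600 nM in this assay, at which 3 of the 3 values shown sit). No step beyond the scatter is therefore expected in either direction. The estimate for compound 4 in this assay is 60000 nM, within 25000 nM to 200000 nM, and the expected step is a step that the limit leaves unreadable from compound 3 to compound 4.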

Compound 4, half-maximal effective concentration: > 36600 nM
Compound 4 ended at the assay's limit; the forecaster's own chance of this, stated with the estimate: 80%; the middle value does not contradict the limit.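

Compound 4 ends at the same limit as compound 1, compound 2 and compound 3, so no step between any of them can be read: the limit of > 36600 nM in this assay, at which 4 of the 4 values shown sit.

The compounds shown leave open what their actual values in this assay are, and so whether any of these changes makes a difference there.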